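Swapping Chloro for Bromo in Compound 3

This account rests on a few compounds, and the source may have more. Where it says the series, first, only, none or still open, it means among the compounds named here.

Measured in an in vivo ADME assay on the whole organism (strain Sprague-Dawley) for pharmacokinetics, with Rattus norvegicus as the target; a higher number here means that a larger share of the oral dose reaches the circulation, a lower number that a smaller share of the oral dose reaches the circulation:

- Compound 1 `CCOC[C@H]1C[C@@](CC(C)C)(C(=O)O)N(C(=O)c2ccc(C(C)(C)C)c(OC)c2)[C@H]1c1nccs1` gives 120%
- Compound 2 `COc1cc(C(=O)N2[C@@H](c3nccs3)[C@H](CO)C[C@@]2(CC(C)C)C(=O)O)ccc1C(C)(C)C` gives 11%
- Compound 3 `CC(C)C[C@@]1(C(=O)O)C[C@H](C(N)=O)[C@H](c2nccs2)N1C(=O)c1ccc(C(C)(C)C)c(Cl)c1` gives 5%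

In this assay compound 3 gives 5%, which lies within the usual scatter of compound 2 at 11%. Both stand far from compound 1 at 120%, and the gap between compound 3 and compound 1 is beyond the scatter.

The next structure is compound 4 `CC(C)C[C@@]1(C(=O)O)C[C@H](C(N)=O)[C@H](c2nccs2)N1C(=O)c1ccc(C(C)(C)C)c(Br)c1`, which carries bromo in place of chloro on an aromatic carbon, ortho to a tert-butyl group and meta to a large group (bromo in place of chloro on an aromatic carbon). Going by the values given here, no measured pair shows this exchange on its own, so the data give no direct guide to its size. The expectation therefore rests on compound 3 at 5%, and no step beyond the scatter is expected. The estimated change is small, a number 1 percentage points higher from compound 3 to compound 4 (within the scatter), and its direction is uncertain. For compound 4 the expected value is 6%, with an estimated range from 1% to 18%.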

Compound 4, oral bioavailability: 2%
Estimate against measurement, compound 4: 4 percentage points above, and the stated range covers the measured number.
By their numbers in this assay, from the lowest: compounds 4, 3 and 2 (each within the scatter of the next); then compound 1.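

Bromo in place of chloro on an aromatic carbon, ortho to a tert-butyl group, gives in this assay a number 3 percentage points lower from compound 3 to compound 4 (within the scatter), the first exchange in this set that can be read on its own. At this position, with everything else in the structure held fixed, the two halogens therefore cannot be told apart in this read-out. Nothing at hand bears on this result.

Still open, going by these compounds, is whether another group at this aromatic carbon, such as fluoro, trifluoromethyl or a nitrile, would also leave the number within the scatter of compound 3. The compounds shown also leave open how a change elsewhere on compound 4, such as an amine or a longer chain in place of the amide group, would behave in this assay.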